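The source may report more compounds than this note shows. Statements on the series, on what has been measured and on what is new or still open speak of the compounds shown alone.

In a functional assay on SK-MEL-28 cells (Homo sapiens) for inhibition (a lower number here means a stronger inhibitor, a higher number a weaker inhibitor), compound 3 (`Cc1ccc(/C=C\c2ccc3ccccc3c2)cc1`) gives no number, only a limit of > 5000 nM. Compound 2 (`Cc1ccc(/C=C/c2ccc3ccccc3c2)cc1`) also reaches only a limit, > 5000 nM. Compound 1 (`COCCOc1cc(/C=C\c2ccc3ccccc3c2)ccc1OC`), with different groups on its ring, gives a measured 2990 nM. Moving to compound 4 (`CN(C)c1ccc(/C=C\c2ccc3ccccc3c2)cc1`), dimethylamino replaces methyl on an aromatic carbon, para to a large group: dimethylamino in place of methyl on an aromatic carbon. Among the compounds with values here, the only measured step, a step that the two limits leave unreadable from compound 2 to compound 3, concerns (the fact that compounds 2 and 3 differ only in the configuration as drawn), so it offers no size for this replacement. With so little to go on, only a slight gain in this assay is expected, guided by compound 1 at 2990 nM. The estimated change is an at least 1.2-fold lower number from compound 3 to compound 4 (0.09 log units; that floor lies within the scatter). For compound 4, the expected value is 4000 nM, with an expected range from 1200 nM to 10000 nM.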

Compound 4, half-maximal inhibitory concentration: 3660 nM
Compound 4: the middle estimate sits 1.1-fold (0.04 log units) above what was measured, within the range that was stated.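

In this assay, dimethylamino in place of methyl on an aromatic carbon, para to a large group, gives an at least 1.3-fold lower number from compound 3 to compound 4 (0.13 log units; that floor lies within the scatter). This change therefore yields a measured value for compound 4, where compound 3 gave none. The true size of the step remains unknown, because compound 3 has only a limit: the limit of > 5000 nM in this assay, at which 2 of the 4 values shown sit.

Going by these compounds, how a primary amine or a carboxylic acid in this place would compare with dimethylamino remains open. So does whether drawing the double bond of compound 4 as E would alter its value.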